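Removing the second methoxy from the bis-methoxy analogue

A few compounds are considered here, and "the series" means these few. Any claim that something is new, unique, unknown or untested is made for them only; others in the source may bear on it.

Compound 2 `COc1ccc2c(/C=C(\C#N)C(=O)c3c[nH]c4cc(OC)ccc34)c[nH]c2c1` in a functional assay on PC-3 cells (Homo sapiens) for cytotoxicity, read by WST assay, with a stated time of 24 h (on this read-out higher numbers stand for weaker inhibition and lower numbers for stronger inhibition), gives only a limit, > 50000 nM. That is the limit of > 50000 nM in this assay, at which 2 of the 3 values shown sit, so compound 2 stands among the weakest-read members. Compound 1 `COc1ccc2[nH]cc(/C=C(\C#N)C(=O)c3c[nH]c4ccccc34)c2c1` gives 33200 nM. Compound 3 `N#C/C(=C\c1c[nH]c2ccccc12)C(=O)c1c[nH]c2ccccc12` gives only a limit, > 50000 nM. Among the measured compounds shown here, the one measured step, an at least 1.5-fold higher number from compound 1 to compound 3 (0.17 log units; that floor lies within the scatter), is the same change as that from compound 2 to compound 4 `COc1ccc2c(C(=O)/C(C#N)=C/c3c[nH]c4ccccc34)c[nH]c2c1`, though at a different place on the shared core: hydrogen in place of methoxy on an aromatic carbon. Since compound 2 starts at a limit, the step of an at least 1.0-fold lower number from compound 2 to compound 4 (0.01 log units; that floor lies within the scatter) is expected to be small and most likely again beyond the assay floor. Compound 4 is therefore estimated at 48000 nM, ranging from 20000 nM to 120000 nM.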

Compound 4, half-maximal inhibitory concentration: > 50000 nM
Compound 4: a limit, no number; the forecaster's own chance of this, stated with the estimate: 60%; middle value at least 1.0-fold (0.01 log units) away from the limit.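

Compound 4 gives only a limit, > 50000 nM. No step from compound 2 or compound 3 to compound 4 can be read, because all three stand at the same limit: the limit of > 50000 nM in this assay, at which 3 of the 4 values shown sit.

Open remains how far compound 2, compound 3 and compound 4 differ from one another in this assay.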